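A Carboxy Group on the Core of Compound 1

The compounds below may be only part of what the source reports. "The series", "measured", "known", "first", "only" and "open" are said of these compounds alone.

- compound 1 `CCCCc1nc2ccccc2nc1Cc1ccc(-c2ccccc2-c2nn[nH]n2)cc1`: 32 nM
- compound 2 `CCCCc1c(Cc2ccc(-c3ccccc3-c3nn[nH]n3)cc2)nc2ccccc2[n+]1[O-]`: 52 nM

Both compounds were tested in a functional assay (aorta) with Rattus norvegicus as the target; on this read-out higher numbers stand for weaker inhibition and lower numbers for stronger inhibition. Compound 1, at 32 nM, cannot be told apart from compound 2, at 52 nM, as the two values lie within the usual scatter of each other. Among the compounds with values here, compound 1 therefore holds no separate rank among the numbers so far.

Compound 3 `CCCCc1nc2cccc(C(=O)O)c2nc1Cc1ccc(-c2ccccc2-c2nn[nH]n2)cc1` keeps the core of compound 1 but has carboxy in place of hydrogen on an aromatic carbon. Within the data shown here, no measured pair shows the effect of this change, so the expectation is a judgement with a wide margin. A moderate step toward stronger inhibition, and so a lower number, is expected in this assay. The expected step is a 3.2-fold lower number from compound 1 to compound 3 (0.51 log units; beyond the scatter). For compound 3 the estimated value is 10 nM, with an expected range of 2 nM to 50 nM.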

Compound 3, antagonist equilibrium constant: 0.49 nM
The estimate for compound 3 lay 20-fold (1.31 log units) above the measured number; measured number outside the range, below it.
By their numbers in this assay, from the lowest: compound 3; then compounds 1 and 2 (each within the scatter of the next).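

In this assay, within the data shown here, carboxy in place of hydrogen on an aromatic carbon of the six-membered aromatic ring of carbon only gives a 65-fold lower number from compound 1 to compound 3 (1.81 log units; beyond the scatter), a large step and the first change to lie clearly beyond the scatter. This position on the core of compound 1 therefore accepts a group of this size, and the change goes with much stronger inhibition rather than a loss. Nothing shown here accounts for the size of this step.

With a single group at a single position, the compounds shown leave open whether the carboxy itself is needed, or whether a methyl ester, a primary amide or a hydroxymethyl group would lower the number as far. They also leave open how carboxy would fare on another aromatic carbon of the same ring.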